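Chain extension at the amide in a melatonin agonist series

The source may report more compounds than this note shows. Statements on the series, on what has been measured and on what is new or still open speak of the compounds shown alone.

Measured compounds:
compound 1, `CCC(=O)NCc1ccc(F)c(OC)c1`: 86%
compound 2, `CCCC(=O)NCc1ccc(F)c(OC)c1`: 75%
compound 3, `CCC(=O)NCCCc1cc(OC)ccc1F`: 100%

All three numbers come from an assay on isolated protein for agonist activity at melatonin receptor type 1C (Xenopus laevis), read by spectrophotometry; on this read-out higher numbers stand for larger maximal responses and lower numbers for smaller maximal responses. Compound 1 and compound 2 share one core and differ only by methyl in place of hydrogen on a saturated chain carbon, two bonds along the chain from a carbonyl carbon; that change brought a number 11 percentage points lower from compound 1 to compound 2 (beyond the scatter). Compound 3 is built on a different core, and the difference between the core of compound 1 and the core of compound 3 is not broken down here. Compound 3 holds the highest of the three numbers in this assay: compound 1 lies beyond the scatter below it, and compound 2 lies further below still.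

The unmeasured compound 4, `CCCC(=O)NCCCc1cc(OC)ccc1F`, stands to compound 3 exactly as compound 2 stands to compound 1. The difference is methyl in place of hydrogen on a saturated chain carbon, two bonds along the chain from a carbonyl carbon, at the same place as before, so it is the same change met a second time, now on the other core. For the measured compounds named here, only one earlier example exists, and it sits on a different core, so the expectation rests on a single step. Compound 4 is expected to fall somewhat below compound 3 because the same change once gave a number 11 percentage points lower from compound 1 to compound 2 (beyond the scatter). Compound 4 is therefore estimated at about 89% in this assay, a step of a number 11 percentage points lower from compound 3 to compound 4 (beyond the scatter), with an expected range from 76% to 100%.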

Compound 4, largest response reached (reported as efficacy), in percent of the reference or control that the assay uses: 100%
Estimate against measurement, compound 4: 11 percentage points below; the range from low to high includes it.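

Methyl in place of hydrogen on a saturated chain carbon, two bonds along the chain from a carbonyl carbon, has now been read on a second core, and in this assay the new step is no change at the digits printed from compound 3 to compound 4 (within the scatter). Set beside the earlier step, the two readings do not separate: the same change on two cores in this assay, a number 11 percentage points lower (beyond the scatter) from compound 1 to compound 2 and no change at the digits printed (within the scatter) from compound 3 to compound 4, 11 percentage points apart, within the scatter of two such steps This shows that the data give no ground for treating the change as acting differently on the two cores, but it does not show that the change carries over as one fixed step, since each core contributes a single pair and the lower number on the core of compound 1 has no counterpart on the core of compound 3.

The compounds shown leave open how a longer chain, a branched chain such as isopropyl or a cyclopropyl group would read in place of the propylcarbonyl chain on either core. Also open, as far as these compounds go, is how an amine or a carboxylic acid at the end of that chain would read in this assay, and whether the change would behave the same way on any further core.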